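A few compounds are considered here, and "the series" means these few. Any claim that something is new, unique, unknown or untested is made for them only; others in the source may bear on it.

Measured compounds:
compound 1, `C[Se]/C(=N\C(=O)c1cc2ccccc2s1)NC(=O)c1cc2ccccc2s1`: 89600 nM
compound 2, `CS/C(=N\C(=O)c1sccc1Cl)NC(=O)c1sccc1Cl`: > 100000 nM

In a functional assay on K562 cells (Homo sapiens) for cytotoxicity, read by MTT assay, with a stated time of 72 h (a lower number here means that less compound is tolerated, a higher number that more compound is tolerated), compound 1 gives 89600 nM, which is the only plain number among the two results shown. Compound 2 in this assay reaches only a limit of the assay, > 100000 nM. That situation is summed up by the limit of > 100000 nM in this assay, at which 1 of the 2 values shown sits.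

Compound 3, `CS/C(=N\C(=O)c1cc2ccccc2s1)NC(=O)c1cc2ccccc2s1`, has not yet been tested in this assay. It differs from compound 1 by a group of 2 heavy atoms (1 carbon, 1 sulfur; no ring) in place of a group of 2 heavy atoms (1 carbon, 1 selenium; no ring), on a carbon with a double bond to nitrogen. Within the data shown here, no pair of measured compounds separated by a single change is available, so the size of this step in this assay cannot be read off; a shift toward a higher number, around the edge of the usual scatter, is expected. Compound 3 is expected to give 130000 nM, with a likely range from 55000 nM to 300000 nM. The expected step from compound 1 to compound 3 in this assay is therefore a 1.5-fold higher number from compound 1 to compound 3 (0.16 log units; within the scatter).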

Compound 3, concentration lethal to 50% of the cells: 98600 nM
Beside the measured number, compound 3's estimate is 1.3-fold (0.12 log units) above it; the measured number falls inside the stated range.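

In this assay, among these compounds, this is the first step that can be read at the carbon with a double bond to nitrogen: putting methylsulfanyl in place of the selenium-bearing group of the same size gives a 1.1-fold higher number from compound 1 to compound 3 (0.04 log units; within the scatter). With the rest of the structure unchanged, selenium and sulfur at this place therefore cannot be told apart in this assay. Any further step toward a higher number would soon meet a limit of the assay, and compound 2 gives only such a limit, not a number: the limit of > 100000 nM in this assay, at which 1 of the 3 values shown sits.

The compounds shown leave open whether a longer chain or an amine on this carbon would move the number beyond the scatter. They also leave open whether the same exchange of selenium for sulfur would read alike on the structure of compound 2.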